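Two inactive analogues and an untested methoxyphenyl variant

The source may hold more compounds than are shown below. What is called first, only, known or untested is meant among the compounds shown, and "the series" means these compounds.

Compound 1, `COc1ccc(-n2nncc2CN2C(=O)C3(C(C#N)=C(N)Oc4c3c3nc5ccccc5nc3c3ccccc43)c3ccccc32)cc1`, in an ADME assay on L02 cells (Homo sapiens) for antiproliferative activity, read by MTT assay, with a stated time of 48 h (a lower number here means a stronger inhibitor, a higher number a weaker inhibitor), gives only the assay limit > 50000 nM.
Compound 2, `Cc1cccc(-n2nncc2CN2C(=O)C3(C(C#N)=C(N)Oc4c(N)cc5nc6ccccc6nc5c43)c3ccccc32)c1`, in this assay likewise gives only the assay limit > 50000 nM.

Neither measured compound yields a number in this assay. Compound 2 therefore stands at the limit of the assay, and it is not alone there: the limit of > 50000 nM in this assay, at which 2 of the 2 values shown sit. Among the compounds with values here, no step between measured compounds can be drawn, since both values are limits and the two compounds differ in more than one place.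

Compound 3, `COc1ccccc1-n1nncc1CN1C(=O)C2(C(C#N)=C(N)Oc3c(N)cc4nc5ccccc5nc4c32)c2ccccc21`, is the next compound to be measured in this assay. It differs from compound 2 in one place: 2-methoxyphenyl in place of 3-methylphenyl on an aromatic nitrogen. Within the data shown here, nothing among the measured compounds shows how a change of this kind shifts the read-out, as both sit at the limit. The step from compound 2 to compound 3 is therefore expected to be none beyond the scatter, and compound 3 is expected to remain at the assay limit as well, with an estimated value of 60000 nM and a range from 20000 nM to 200000 nM, corresponding to an expected step that the limit leaves unreadable from compound 2 to compound 3.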

Compound 3, half-maximal inhibitory concentration: > 50000 nM
Compound 3 was reported as a limit (the forecaster's own chance of this, stated with the estimate: 85%); the middle value does not contradict the limit.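

Compound 3 and compound 2 are both reported only as limits in this assay, so no step between them can be read: the limit of > 50000 nM in this assay, at which 3 of the 3 values shown sit.

The compounds shown leave open what the true read-out of compound 1, compound 2 or compound 3 is, and whether 2-methoxyphenyl in place of 3-methylphenyl changes it at all.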